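Fluoro on the Central Ring: What to Expect of Compound 4

The compounds below may be only part of what the source reports. "The series", "measured", "known", "first", "only" and "open" are said of these compounds alone.

Compound 1 `Cn1ccc2c(Oc3ccc(NC(=O)c4cc5cccnc5n(-c5ccc(F)cc5)c4=O)cc3)ccnc21` gives 210 nM in a functional assay on A549 cells (Homo sapiens) for antiproliferative activity, read by MTT assay, with a stated time of 72 h; on this read-out lower numbers stand for stronger inhibition and higher numbers for weaker inhibition. Compound 2 `COc1ccc(-n2c(=O)c(C(=O)Nc3ccc(Oc4ccnc5c4ccn5C)cc3)cc3cccnc32)cc1` gives 3460 nM in this assay. Compound 3 `Cn1ccc2c(Oc3ccc(NC(=O)c4cc5cccnc5n(-c5ccc(F)c(Cl)c5)c4=O)cc3)ccnc21` gives 820 nM in this assay.

Among these three, compound 1 stands lowest: compound 3 is nearest, with a 3.9-fold higher number from compound 1 to compound 3 (0.59 log units; beyond the scatter), and compound 2 furthest, with a 16-fold higher number from compound 1 to compound 2 (1.22 log units; beyond the scatter). Compound 4 `Cn1ccc2c(Oc3ccc(NC(=O)c4cc5cccnc5n(-c5ccc(F)cc5)c4=O)cc3F)ccnc21` differs from compound 1 by fluoro in place of hydrogen on an aromatic carbon. Among the measured compounds shown here, all the measured steps change the ring on the aromatic nitrogen instead: a 16-fold higher number from compound 1 to compound 2 (1.22 log units; beyond the scatter) was large, while a 3.9-fold higher number from compound 1 to compound 3 (0.59 log units; beyond the scatter) and a 4.2-fold lower number from compound 2 to compound 3 (0.63 log units; beyond the scatter) were modest. None of them touches the ring altered in compound 4, so they bear on it only loosely; the closest analogy is compound 3, where a 3.9-fold higher number from compound 1 to compound 3 (0.59 log units; beyond the scatter) followed an added halogen. A small added fluoro is expected to move the number less than that, in the weaker direction if at all. Compound 4 is therefore expected to give 320 nM in this assay, within 120 nM to 900 nM, with a 1.5-fold higher number from compound 1 to compound 4 (0.18 log units; within the scatter) expected to sit near the edge of the scatter.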

Compound 4, half-maximal inhibitory concentration: 280 nM
Beside the measured number, compound 4's estimate is 1.1-fold (0.06 log units) above it; the measured number falls inside the stated range.
By their numbers in this assay, from the lowest: compounds 1 and 4 (each within the scatter of the next); then compound 3; then compound 2.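

In this assay, fluoro in place of hydrogen on the six-membered aromatic ring of carbon only, ortho to a large group and meta to a large group, gives a 1.3-fold higher number from compound 1 to compound 4 (0.12 log units; within the scatter). Among the compounds shown here, this is the first sign that the shared core accepts a change on this ring without a step beyond the scatter, whereas the changes on the aromatic nitrogen in compound 2 and compound 3 each moved the number beyond it. The data shown offer no measurement that accounts for this result.

Going by these compounds, it remains open whether an amine or a carboxylic acid at this same place would also stay within the scatter of compound 1. Also open, on these data alone, is whether fluoro here would behave alike with the 3-chloro-4-fluorophenyl ring of compound 3 or the 4-methoxyphenyl ring of compound 2 on the aromatic nitrogen.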